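A few compounds are considered here, and "the series" means these few. Any claim that something is new, unique, unknown or untested is made for them only; others in the source may bear on it.

Compound 1 `COC[C@H](C(C)C)C(c1ccc(O)c(OC)c1)c1ccc(O)c(OC)c1` carries two phenol rings joined through a single chain carbon, and its chain bears a methoxymethyl branch beside an isopropyl branch. In a functional assay on HeLa cells (Homo sapiens) for cytotoxicity, read by WST assay, with a stated time of 48 h (on this read-out higher numbers stand for weaker inhibition and lower numbers for stronger inhibition), compound 1 gives 76000 nM, the only numerical result among the compounds described here. Compound 2 `COc1ccc(C(c2ccc(OC)c(OC)c2)[C@H](C)[C@H](C)CO)cc1OC`, a close relative in which every phenol is capped as a methoxy ether and the chain carries a hydroxymethyl branch, returns in this assay only a limit of > 100000 nM, and that limit of > 100000 nM in this assay, at which 1 of the 2 values shown sits, is the sole other outcome recorded. Among the measured compounds shown here, because the two compounds differ in more than one place, no single step is drawn from compound 1 to compound 2, and their two values show only that one is a number and the other a limit.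

Compound 3 `COc1cc(C(c2ccc(O)c(OC)c2)[C@H](C)C(C)C)ccc1O` is the compound that remains to be measured. It differs from compound 1 by hydrogen in place of methoxy on a saturated chain carbon, three bonds along the chain from two aromatic carbons. For the measured compounds named here, no measured pair reports what such a change does in this assay, so the expected step from compound 1 to compound 3 is set at a 1.1-fold higher number from compound 1 to compound 3 (0.05 log units; within the scatter), a change not beyond the scatter in either direction. On that basis compound 3 is estimated to give 85000 nM, with a range from 35000 nM to 200000 nM.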

Compound 3, half-maximal inhibitory concentration: 16000 nM
Compound 3: the middle estimate sits 5.3-fold (0.73 log units) above what was measured; measured number outside the range, below it.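

Hydrogen in place of methoxy on a saturated chain carbon, three bonds along the chain from two aromatic carbons, gives the first change of readable size in this assay: a 4.8-fold lower number from compound 1 to compound 3 (0.68 log units; beyond the scatter). This shows that the position is not silent on this read-out, as cutting the methoxymethyl back to methyl, which turns the 1-(methoxymethyl)-2-methylpropyl chain into the 1,2-dimethylpropyl chain, moves the number beyond the scatter towards stronger inhibition. The compounds shown offer no measured property that would account for this step.

Among the compounds shown here, the single step leaves open whether the methoxy oxygen or the length of the branch matters here, and an ethyl or an aminomethyl group at this carbon would be needed to tell the two apart. It also leaves open whether the same change would carry the same size on a core whose phenols are capped as methoxy ethers, or in any read-out other than this assay.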